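Removing the tert-butyl group from compound 1

This account rests on a few compounds, and the source may have more. Where it says the series, first, only, none or still open, it means among the compounds named here.

Compound 1 `CCN(CC)Cc1ccc2nc(NC(=O)N/N=C/c3cn(Cc4ccc(C(C)(C)C)cc4)c4ccccc34)sc2c1`: 1710 nM
Compound 2 `CN(C)Cc1ccc2nc(NC(=O)N/N=C/c3cn(Cc4ccc(C(C)(C)C)cc4)c4ccccc34)sc2c1`: 1850 nM
Compound 3 `CN(C)Cc1ccc2nc(NC(=O)N/N=C/c3cn(Cc4ccc(Cl)cc4)c4ccccc34)sc2c1`: 840 nM

In a functional assay on A549 cells (Homo sapiens) for cytotoxicity, read by MTT assay, with a stated time of 72 h (a lower number here means a stronger inhibitor, a higher number a weaker inhibitor), compound 1 gives 1710 nM, the second highest of the three numbers. Compound 2 lies a 1.1-fold higher number from compound 1 to compound 2 (0.03 log units; within the scatter), so the two cannot be told apart. Going by the values given here, compound 3 stands furthest from compound 1, with a lower number, and the only step beyond the scatter is a 2.2-fold lower number from compound 2 to compound 3 (0.34 log units; beyond the scatter).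

Compound 4 `CCN(CC)Cc1ccc2nc(NC(=O)N/N=C/c3cn(Cc4ccccc4)c4ccccc34)sc2c1` has not yet been measured. It differs from compound 1 in one place: hydrogen in place of tert-butyl on an aromatic carbon.

Among the compounds with values here, no measured step shows exactly this change. The nearest guide is the step from compound 2 to compound 3, where a smaller group replaced tert-butyl on the same aromatic carbon and the number fell modestly. The step to compound 4 removes that group entirely, so a similar or smaller shift is expected. Compound 4 is therefore estimated at 1200 nM, with a range from 500 nM to 3000 nM, meaning an expected step of a 1.4-fold lower number from compound 1 to compound 4 (0.15 log units; within the scatter).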

Compound 4, half-maximal inhibitory concentration: 3330 nM
Compound 4: the middle estimate sits 2.8-fold (0.44 log units) below what was measured; the measured number lies above the stated range.
By their numbers in this assay, from the lowest: compound 3; then compounds 1, 2 and 4 (each within the scatter of the next).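

Taking the tert-butyl group off this aromatic carbon removes all four of its heavy atoms, yet in this assay the result is a 1.9-fold higher number from compound 1 to compound 4 (0.29 log units; within the scatter), so compound 1 and compound 4 cannot be told apart. On this diethylamino compound, then, the 4-(tert-butyl)benzyl group can be cut back to benzyl with no readable change, whereas chloro in place of tert-butyl on the dimethylamino compounds gave a 2.2-fold lower number from compound 2 to compound 3 (0.34 log units; beyond the scatter). No measurement here explains either result.

Open still is how a methoxy group or an amine on this aromatic carbon would read. Also open, as far as these compounds go, is whether chloro in place of tert-butyl would give a step beyond the scatter on the diethylamino compound as well.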